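Benzimidazole acid to aminobenzoic acid on the piperidine core

This account rests on a few compounds, and the source may have more. Where it says the series, first, only, none or still open, it means among the compounds named here.

Of the compounds shown here, three that share one core have been measured in an assay on isolated protein for activation of cGMP-dependent protein kinase 1 (Homo sapiens), read by ADP-Glo, with stated times of 30 min and 2 h, in the presence of a further agent that is not named here; on this read-out higher numbers stand for an effect only at larger amounts of compound and lower numbers for an effect already at smaller amounts. Compound 1 `COC(=O)c1ccc(CN2CCC[C@H](O[C@H](CO)c3cc(Cl)cc(Cl)c3)[C@@H]2c2ccccc2)c(C)c1` gives 900 nM. Compound 2 `Cc1cc(C(=O)O)ccc1C(C)N1CCC[C@H](O[C@H](CO)c2cc(Cl)cc(Cl)c2)[C@@H]1c1ccccc1` gives 18000 nM, and the change from a 20-fold higher number from compound 1 to compound 2 (1.30 log units; beyond the scatter). Compound 3 `O=C(O)c1ccc2nc(CN3CCC[C@H](O[C@H](CO)c4cc(Cl)cc(Cl)c4)[C@@H]3c3ccccc3)[nH]c2c1` gives 380 nM, the lowest of the three numbers; its nearest neighbour is compound 1, and compound 2 stands far above it. The step from a 2.4-fold lower number from compound 1 to compound 3 (0.37 log units; beyond the scatter).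

Compound 4 `Nc1cc(C(=O)O)ccc1CN1CCC[C@H](O[C@H](CO)c2cc(Cl)cc(Cl)c2)[C@@H]1c1ccccc1` has not yet been measured in this assay. It differs from compound 3 in one place: a group of 10 heavy atoms (7 carbon, 1 nitrogen, 2 oxygen; one six-membered aromatic ring of carbon only) in place of a group of 12 heavy atoms (8 carbon, 2 nitrogen, 2 oxygen; one five-membered aromatic ring with 2 hetero atoms, one six-membered aromatic ring of carbon only), on a saturated chain carbon bound to an amine nitrogen in a ring. Among the measured compounds shown here, no measured step matches this change directly. The step from compound 1 to compound 3 bears on it only loosely, since it shows that the group carrying the acid on this carbon can move the number by a modest amount, while the step from compound 1 to compound 2, which involves a different change on the ring nitrogen, does not speak to it. Compound 4 keeps the free acid of compound 3 but loses the five-membered ring, so a small to modest rise in the number is expected, as the step of a 1.6-fold higher number from compound 3 to compound 4 (0.20 log units; within the scatter) states. For compound 4 the estimated value in this assay is 600 nM, with a range from 200 nM to 2000 nM.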

Compound 4, half-maximal effective concentration: 290 nM
Compound 4: middle estimate off by 2.1-fold (0.32 log units), on the high side; measured number inside the range.
By their numbers in this assay, from the lowest: compounds 4 and 3 (each within the scatter of the next); then compound 1; then compound 2.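

In this assay the 2-amino-4-carboxyphenyl group, with one six-membered aromatic ring of carbon only, stands in place of the two-ring group of compound 3 on a saturated chain carbon bound to an amine nitrogen in a ring, and a 1.3-fold lower number from compound 3 to compound 4 (0.12 log units; within the scatter) shows that the five-membered aromatic ring is not needed to hold the number at this level. At the same place, a 3.1-fold lower number from compound 1 to compound 4 (0.49 log units; beyond the scatter) shows that this group keeps the advantage over the group of compound 1 that the two-ring group had already shown. Read as a change on the amine nitrogen in a ring, a 62-fold lower number from compound 2 to compound 4 (1.79 log units; beyond the scatter) sets the whole group of compound 4 far apart from that of compound 2, which also carries a carboxylic acid, so the acid alone does not bring the number down.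

No measurement at hand explains why the two groups of compound 3 and compound 4 give such similar numbers. The compounds shown also leave open how much the amine on the benzene ring contributes, as against a hydrogen, a hydroxyl or a methyl there, and whether a methyl ester or an amide could stand in for the carboxylic acid of compound 4.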